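A few compounds are considered here, and "the series" means these few. Any claim that something is new, unique, unknown or untested is made for them only; others in the source may bear on it.

Going by the values given here, in an ADME assay on MT4 cells (Homo sapiens) for cytotoxicity, read by MTT assay, with a stated time of 5 days (a higher number here means that more compound is tolerated, a lower number that less compound is tolerated), compound 2 `Cc1cc(/C=C/C#N)cc(C)c1Oc1nc(Nc2ccc(CN3CCNCC3)cc2)nc2ccsc12` gives 3970 nM, the lower of the two numbers available, since compound 1 `Cc1cc(/C=C/C#N)cc(C)c1Oc1nc(Nc2ccc(CN3CCN(S(C)(=O)=O)CC3)cc2)nc2ccsc12` gives 20700 nM; the single measured step is a 5.2-fold lower number from compound 1 to compound 2 (0.72 log units; beyond the scatter). Compound 3 `Cc1cc(/C=C/C#N)cc(C)c1Oc1nc(Nc2ccc(N3CCCC(N)C3)cc2)nc2ccsc12` differs from compound 2 by 3-aminopiperidin-1-yl in place of (piperazin-1-yl)methyl on an aromatic carbon. Among the compounds with values here, no measured step covers this kind of rearrangement, and the one known step concerns a different part of the molecule, so it offers no direction. One therefore expects a step from compound 2 to compound 3 of about a 1.1-fold lower number from compound 2 to compound 3 (0.05 log units; within the scatter), within the scatter. Compound 3 is estimated at 3500 nM, with a range from 1200 nM to 10000 nM.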

Compound 3, half-maximal cytotoxic concentration: 3820 nM
Estimate against measurement, compound 3: 1.1-fold (0.04 log units) below; the range from low to high includes it.
By their numbers in this assay, from the lowest: compounds 3 and 2 (each within the scatter of the next); then compound 1.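

In this assay, 3-aminopiperidin-1-yl in place of (piperazin-1-yl)methyl on the aromatic carbon gives a 1.0-fold lower number from compound 2 to compound 3 (0.02 log units; within the scatter), so this change of ring and attachment does not separate the two compounds. Set against compound 1, which carries methylsulfonyl, the result is a 5.4-fold lower number from compound 1 to compound 3 (0.73 log units; beyond the scatter) on this read-out, so a second compound without that group also stands apart from compound 1. No available evidence explains these numbers. The compounds shown leave open how a morpholine ring or an acetyl group on the ring nitrogen would read in this assay.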